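Moving the carboxylic acid and trading hydroxyl for methyl

The source may report more compounds than this note shows. Statements on the series, on what has been measured and on what is new or still open speak of the compounds shown alone.

Measured compounds:
compound 1 `O=C(O)c1cc(-c2cccc(COc3ccc4c(c3)CN(C3CCCC3)C4=O)c2)ccc1O`: 20 nM
compound 2 `O=C(O)c1cc(-c2cccc(COc3ccc4c(=O)n(C5CCCC5)sc4c3)c2)ccc1F`: 240 nM

In an assay on HEK293 cells for positive allosteric modulation of metabotropic glutamate receptor 2 (Rattus norvegicus), read by thallium flux (a lower number here means that less compound is needed, a higher number that more compound is needed for the effect), compound 1 gives 20 nM, the lower of the two numbers; compound 2 gives 240 nM, a gap beyond the scatter. Compound 3 `Cc1ccc(C(=O)O)cc1-c1cccc(COc2ccc3c(c2)CN(C2CCCC2)C3=O)c1` differs from compound 1 by 5-carboxy-2-methylphenyl in place of 3-carboxy-4-hydroxyphenyl on an aromatic carbon. Within the data shown here, because compound 1 stands at 20 nM and no single-change pair has been measured, the effect of the change is uncertain; the step of a 7.5-fold higher number from compound 1 to compound 3 (0.88 log units; beyond the scatter) is expected to be a loss beyond the scatter. Compound 3 is estimated at 150 nM, within 40 nM to 600 nM.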

Compound 3, half-maximal effective concentration: 110 nM
For compound 3 the middle estimate is 1.4-fold (0.13 log units) above the measured one; measured number inside the range.
By their numbers in this assay, from the lowest: compound 1; then compound 3; then compound 2.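

In this assay, 5-carboxy-2-methylphenyl in place of 3-carboxy-4-hydroxyphenyl gives a 5.5-fold higher number from compound 1 to compound 3 (0.74 log units; beyond the scatter), the only single-change pair shown, and a loss at this position. The step combines two edits, moving the carboxylic acid and trading hydroxyl for methyl, so it prices them only together. Nothing measured here explains the loss.

Which of the two edits accounts for the step remains open. So does whether an amine or a methoxy group in place of the methyl would bring the number closer to that of compound 1.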